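The source may hold more compounds than are shown below. What is called first, only, known or untested is meant among the compounds shown, and "the series" means these compounds.

Compound 1 `CCN(CC)C(=O)CN(c1ccc(C)cc1)S(=O)(=O)c1ccc(OC(F)(F)F)cc1` is the reference point for this step. In a functional assay on CHO cells for inhibition of Orexin/Hypocretin receptor type 1 (Homo sapiens), read by FLIPR and calcium flux (on this read-out higher numbers stand for weaker inhibition and lower numbers for stronger inhibition), compound 1 gives only a limit, > 10000 nM, so its place among the numbers shown cannot be fixed beyond that. Compound 2 `CCN(CC)C(=O)CN(c1cc(N(CC)CC)ccc1Cl)S(=O)(=O)c1ccc(OC)c(OC)c1` likewise returns a limit in this assay, > 10000 nM. Going by the values given here, compound 3 `CCN(CC)C(=O)CN(c1cc(N2CCCC2)ccc1Cl)S(=O)(=O)c1ccc(OC)c(OC)c1` gives 2530 nM in this assay; the single measured step, an at least 3.9-fold lower number from compound 2 to compound 3 (0.59 log units; beyond the scatter), concerns pyrrolidin-1-yl in place of diethylamino on an aromatic carbon and not the sulfonyl aryl. Compound 4 `CCN(CC)C(=O)CN(c1ccc(C)cc1)S(=O)(=O)c1ccc(OC)cc1` differs from compound 1 by methyl in place of trifluoromethyl on an oxygen on an aromatic ring. Among the compounds with values here, no measured step covers this change, and two of the three values sit at the limit of > 10000 nM in this assay, at which 2 of the 3 values shown sit. Compound 4 is therefore expected to remain near the limit, estimated at 15000 nM within 4000 nM to 60000 nM, an expected step that the limit leaves unreadable from compound 1 to compound 4.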

Compound 4, half-maximal inhibitory concentration: > 10000 nM
Compound 4 gave a limit, no number; the forecaster's own chance of this, stated with the estimate: 70%; the middle value lies beyond the limit too.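

No step can be read from compound 1 to compound 4, since both values stop at a limit: the limit of > 10000 nM in this assay, at which 3 of the 4 values shown sit. The compounds shown leave open whether trifluoromethoxy to methoxy alters inhibition at all.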